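Methylation of a phenol hydroxy in a cytotoxicity series

The source may hold more compounds than are shown below. What is called first, only, known or untested is meant among the compounds shown, and "the series" means these compounds.

Compound 1 `CCCc1cc(O)c(Cl)c(O)c1Oc1c(Cl)c(O)c(Cl)c2c1C(=O)O[C@@H]2CC` was examined in an ADME assay on MDCK cells (Canis lupus familiaris) for cytotoxicity, read by CellTiter-Glo, with a stated time of 40 h; a lower number here means that less compound is tolerated, a higher number that more compound is tolerated. In this assay compound 1 gives > 100000 nM, which is a limit of the assay and not a number. Compound 2 `CCCc1cc(O)cc(O)c1Oc1c(Cl)c(O)c(Cl)c2c1C(=O)O[C@@H]2CC` differs from compound 1 by hydrogen in place of chloro on an aromatic carbon. In this assay compound 2 gives > 100000 nM, again a limit rather than a number. The step that the two limits leave unreadable from compound 1 to compound 2 is therefore of a size that cannot be read. Compound 1 thus stands only at the limit of > 100000 nM in this assay, at which 2 of the 2 values shown sit, with no measured number to place it more precisely. Compound 3 `CCCc1cc(O)c(Cl)c(OC)c1Oc1c(Cl)c(O)c(Cl)c2c1C(=O)O[C@@H]2CC` carries the change (methyl in place of hydrogen on an oxygen on an aromatic ring). No measured step bears on this change, since the one step shown is unreadable. Compound 3 is therefore expected to remain at the limit, with an estimated step that the limit leaves unreadable from compound 1 to compound 3. The estimate for compound 3 is 150000 nM, in the range 50000 nM to 500000 nM.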

Compound 3, half-maximal cytotoxic concentration: > 100000 nM
Compound 3 ended at the assay's limit; the forecaster's own chance of this, stated with the estimate: 80%; the middle value is on the limit's open side.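

In this assay, for the compounds shown here, compound 3 gives > 100000 nM, a limit of the assay and not a number, so no step between compound 1 and compound 3 can be read. The compounds shown leave open what change hydroxy to methoxy makes in this assay, as all of them stand at one limit: the limit of > 100000 nM in this assay, at which 3 of the 3 values shown sit.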